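Swapping in 3,5-dimethylphenyl: from compound 2 to compound 3

The source may hold more compounds than are shown below. What is called first, only, known or untested is meant among the compounds shown, and "the series" means these compounds.

In a functional assay on DU-145 cells (Homo sapiens) for inhibition, read by trypan blue exclusion, with a stated time of 96 h (a higher number here means a weaker inhibitor of growth, a lower number a stronger inhibitor of growth), compound 1 (`Cc1ccc(S/C(=C/c2sccc2C)C(=O)c2ccc(Br)cc2)cc1`) gives 50000 nM and compound 2 (`Cc1ccc(S/C(=C/c2sccc2C)C(=O)c2ccc(Cl)cc2)cc1`) gives 50000 nM. Going by the values given here, compound 2 therefore stands level with compound 1, its only neighbour so far. Among the compounds with values here, the one measured step, chloro in place of bromo on an aromatic carbon, shows no change at the digits printed from compound 1 to compound 2 (within the scatter).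

Compound 3 (`Cc1ccc(S/C(=C/c2cc(C)cc(C)c2)C(=O)c2ccc(Cl)cc2)cc1`) keeps the chloro group of compound 2 and carries 3,5-dimethylphenyl in place of 3-methylthiophen-2-yl on a double-bonded chain carbon bound to a double-bonded chain carbon. Within the data shown here, the halogen step does not touch this group, so it bears on the new change only indirectly, and no measured compound carries anything other than 3-methylthiophen-2-yl there. The expectation therefore starts from compound 2 at 50000 nM, and the range is kept wide in both directions. No step beyond the scatter is expected, the estimated step being a 1.3-fold lower number from compound 2 to compound 3 (0.10 log units; within the scatter). In this assay the estimate for compound 3 is 40000 nM, with an expected range of 10000 nM to 80000 nM.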

Compound 3, concentration for 50% growth inhibition: 50000 nM
Compound 3: the middle estimate sits 1.3-fold (0.10 log units) below what was measured; the range from low to high includes it.
By their numbers in this assay, from the lowest: compounds 1, 2 and 3 (each within the scatter of the next).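

In this assay the position on a double-bonded chain carbon bound to a double-bonded chain carbon now has a second group, and 3,5-dimethylphenyl in place of 3-methylthiophen-2-yl gives no change at the digits printed from compound 2 to compound 3 (within the scatter). Until now the series showed only a halogen exchange, with 3-methylthiophen-2-yl held fixed at this position, whereas this step exchanges a five-membered aromatic ring with 1 hetero atom and 6 heavy atoms for a six-membered aromatic ring of carbon only with 8 heavy atoms, and it also goes from 1 hydrogen-bond acceptor to 0 hydrogen-bond acceptors, yet compound 3 gives 50000 nM in this assay with the chloro group unchanged. Nothing independent of these growth readings is available to account for this result.

The compounds shown leave open whether any replacement at this position separates from compound 2 in this assay, since both aromatic groups read alike here. A carboxylic acid, an amine or a longer chain carrying a hydroxyl group in place of 3,5-dimethylphenyl would test that question, and the outcome cannot be inferred from the compounds shown.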